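The source may report more compounds than this note shows. Statements on the series, on what has been measured and on what is new or still open speak of the compounds shown alone.

Working notes on a small series built on one shared core, checked in an ADME assay on J774 cells (Mus musculus) for cytotoxicity, read by MTT assay, with a stated time of 48 h, tested at 50 ug/mL; a lower number here means a stronger effect, a higher number a weaker effect of the compound at the concentration tested. Compound 1 `O=C(N/N=C/c1cccc(Cl)c1)c1cnccn1` gives 100% in this assay. Compound 2 `O=C(N/N=C/c1ccc(O)cc1)c1cnccn1` gives 100% in this assay. Compound 1 stands level with compound 2 at the digits given; the two readings lie within the scatter of each other, so no order between them is drawn. Across the two measured compounds, the group carried on the six-membered aromatic ring of carbon only changes without moving the reading.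

Next is compound 3 `N#Cc1cccc(/C=N/NC(=O)c2cnccn2)c1`, not yet measured in this assay. Its change from compound 1 is cyano in place of chloro on an aromatic carbon. Among the measured compounds shown here, no measured pair shows a step of this kind. Since compound 1 gives 100% and compound 2 gives 100%, a change of the group on this ring is not expected to move the reading beyond the scatter. The expected step is no change at the digits printed from compound 1 to compound 3 (within the scatter). Compound 3 is thus expected to give about 100% in this assay, within 88% to 105%.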

Compound 3, a percentage reported as activity, at one concentration (the size of the read-out at that concentration, not a potency): 100%
Compound 3: the middle estimate sits on the measured number at the digits printed, within the range that was stated.
By their numbers in this assay, from the lowest: compounds 1, 2 and 3 (each within the scatter of the next).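

At this place, meta to a large group on the six-membered aromatic ring of carbon only, cyano in place of chloro gives no change at the digits printed from compound 1 to compound 3 (within the scatter) in this assay. Unlike the earlier pair, this is a step at a single place, and it shows that a group bringing a triple bond outside aromatic rings and a hydrogen-bond acceptor leaves the reading where the chloro group had it. Nothing available on the series explains this flat result.

All three readings sit at one level. The compounds shown do not establish whether any group at this place can lower the reading. An amine, a carboxylic acid or a longer chain here remains an open case, as do changes to the shared core outside this ring.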